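Replacing the pyrazolyl group on the amine nitrogen

This account rests on a few compounds, and the source may have more. Where it says the series, first, only, none or still open, it means among the compounds named here.

Measured so far in a functional assay on MDA-MB-361 cells (Homo sapiens) for antiproliferative activity, read by MTT assay, with a stated time of 72 h (on this read-out lower numbers stand for stronger inhibition and higher numbers for weaker inhibition), as follows:
- compound 1 `CSC[C@H](N/C=C1\C(=O)NN=C1c1ccccc1)C(=O)O` gives 97400 nM
- compound 2 `Cc1cc(N/C=C2\C(=O)N(c3ccccc3)N=C2c2ccccc2)n[nH]1` gives 9980 nM
- compound 3 `O=C1/C(=C\Nc2cc[nH]n2)C(c2ccccc2)=NN1c1ccccc1` gives 51000 nM

Compound 3 at 51000 nM lies within the scatter of compound 1 and beyond the scatter from compound 2. Compound 4 `CSC[C@H](N/C=C1\C(=O)N(c2ccccc2)N=C1c1ccccc1)C(=O)O` differs from compound 3 by 1-carboxy-2-(methylsulfanyl)ethyl in place of 1H-pyrazol-3-yl on an amine nitrogen and is still to be measured in this assay on the same core.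

For the measured compounds named here, the one measured step is a 5.1-fold higher number from compound 2 to compound 3 (0.71 log units; beyond the scatter) with hydrogen in place of methyl on an aromatic carbon. Going by the values given here, it shows only that an edit within the leaving group moved the number, and no measured step covers the exchange itself. Compound 1 carries the entering 1-carboxy-2-(methylsulfanyl)ethyl on a different core and gives 97400 nM within the scatter of compound 3, which offers no sign of a large move.

The expected step is a 1.0-fold lower number from compound 3 to compound 4 (0.01 log units; within the scatter) and none beyond the scatter is expected. For compound 4 the estimated value is 50000 nM with an expected range of 15000 nM to 150000 nM in this read-out.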

Compound 4, half-maximal inhibitory concentration: 14200 nM
Beside the measured number, compound 4's estimate is 3.5-fold (0.55 log units) above it; the whole stated range lies above it.
By their numbers in this assay, from the lowest: compounds 2 and 4 (each within the scatter of the next); then compounds 3 and 1 (each within the scatter of the next).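

In this assay, for the compounds shown here, the step of a 3.6-fold lower number from compound 3 to compound 4 (0.56 log units; beyond the scatter) shows that the exchange on the amine nitrogen itself moves the number, which no earlier step covered. With 5-methyl-1H-pyrazol-3-yl as the leaving group, the step of a 1.4-fold higher number from compound 2 to compound 4 (0.15 log units; within the scatter) gives no separation, so at this position 1-carboxy-2-(methylsulfanyl)ethyl is matched by the methylated ring but not by the unmethylated one. Going by these compounds alone, with that chain held constant, phenyl on the amide-type nitrogen in a ring gives the first reading at that place, the step of a 6.9-fold lower number from compound 1 to compound 4 (0.84 log units; beyond the scatter) in this series.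

Still open, going by these compounds, is which part of the chain carries the step, a question that a methyl ester or a primary amide in place of the carboxylic acid could address. No evidence available here accounts for these steps.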